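Replacing the Ring Phenyl With Methyl in Compound 2

The source may report more compounds than this note shows. Statements on the series, on what has been measured and on what is new or still open speak of the compounds shown alone.

Compound 1 `O=C1C(Cc2n[nH]c3cc(F)ccc23)C(=O)N(c2ccccc2)C=CN1CC(=O)N1CCCCc2ccccc21`, compound 2 `CC(C)N(C(=O)CN1C=CN(c2ccccc2)C(=O)C(Cc2n[nH]c3cc(F)ccc23)C1=O)c1ccc(F)cc1` and compound 3 `CC(C)N(C(=O)CN1C=CN(c2ccccc2)C(=O)[C@H](Cc2n[nH]c3cc(F)ccc23)C1=O)c1ccccc1` share a common core and were all tested in a functional assay on CHO cells for agonist activity at Melanocyte-stimulating hormone receptor (Homo sapiens), read by a luciferase reporter, with a stated time of 4 h; a lower number here means that less compound is needed, a higher number that more compound is needed for the effect. Compound 1 gives 1.59 nM, compound 2 gives 14.1 nM, and compound 3 gives 35.5 nM. Compound 2 therefore stands second highest of the three numbers, with compound 1 below it and compound 3 above it, both gaps beyond the scatter. For the measured compounds named here, the one measured step, an 8.9-fold higher number from compound 1 to compound 2 (0.95 log units; beyond the scatter), concerns the group on the carbonyl carbon of the side chain and leaves the ring nitrogen untouched. Compound 4 `CC(C)N(C(=O)CN1C=CN(C)C(=O)C(Cc2n[nH]c3cc(F)ccc23)C1=O)c1ccc(F)cc1` differs from compound 2 in exactly that untouched place: methyl in place of phenyl on an amide-type nitrogen in a ring. None of the measured compounds varies this group, so no step shown here bears directly on the change, and the expectation must rest on the size of the exchange alone. A step beyond the scatter toward a higher number is expected, estimated as a 4.3-fold higher number from compound 2 to compound 4 (0.63 log units; beyond the scatter). Compound 4 is thus expected to give 60 nM in this assay, with a range from 15 nM to 300 nM.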

Compound 4, half-maximal effective concentration: 3720 nM
Compound 4: middle estimate off by 62-fold (1.79 log units), on the low side; measured number outside the range, above it.
By their numbers in this assay, from the lowest: compound 1; then compound 2; then compound 3; then compound 4.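

Exchanging phenyl for methyl on the amide-type nitrogen in a ring gives a 260-fold higher number from compound 2 to compound 4 (2.42 log units; beyond the scatter) in this assay. For the compounds shown here, this place, which no earlier compound varied, therefore shows a much larger step than the change on the carbonyl carbon of the side chain, an 8.9-fold higher number from compound 1 to compound 2 (0.95 log units; beyond the scatter), and with methyl here far more compound is needed for the effect. Nothing available accounts for this loss.

From the compounds shown here alone, with only phenyl and methyl seen at this place, it remains open whether the aromatic ring itself counts or whether a butyl chain or a cyclohexyl ring would serve as well. Going by these compounds, it also remains open whether the same exchange would give a step of similar size on the side chain of compound 1.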